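The source may report more compounds than this note shows. Statements on the series, on what has been measured and on what is new or still open speak of the compounds shown alone.

Compound 1 `CC(C)CCn1ccc(-c2ccc(Oc3ccccn3)cc2)c(C#N)c1=O`, compound 2 `CC(C)CCn1ccc(-c2ccc(Oc3ccncc3)cc2)c(C#N)c1=O` and compound 3 `Cc1cc(Oc2ccc(-c3ccn(CCC(C)C)c(=O)c3C#N)cc2)ccn1` share one core and differ only in the group carried on an oxygen on an aromatic ring. In a functional assay on CHO cells for positive allosteric modulation of metabotropic glutamate receptor 2 (Homo sapiens), read by scintillation counting and GTPgammaS binding, with a stated time of 30 min (a lower number here means a smaller maximal response, a higher number a larger maximal response), compound 1 gives 249%, compound 2 gives 245% and compound 3 gives 266%. Compound 3 thus stands highest of the three: putting 2-methylpyridin-4-yl in place of pyridin-2-yl brings a number 17 percentage points higher from compound 1 to compound 3 (beyond the scatter), and putting methyl in place of hydrogen on an aromatic carbon brings a number 21 percentage points higher from compound 2 to compound 3 (beyond the scatter), while a number 4 percentage points lower from compound 1 to compound 2 (within the scatter) stays within the scatter. Compound 4 `Cc1cc(Oc2ccc(-c3ccn(CC4CCC4)c(=O)c3C#N)cc2)ccn1` leaves that whole side untouched and alters the chain on the aromatic nitrogen: cyclobutyl in place of isobutyl on a saturated chain carbon bound to an aromatic nitrogen. For the measured compounds named here, none of the measured steps concerns this chain; all three measured compounds carry isopentyl there, so the measurements offer no direct guide to a rise or a fall. With that absence of guidance, the step in this assay is expected to be small, a number 4 percentage points lower from compound 3 to compound 4 (within the scatter), with no direction favoured. Compound 4 is therefore estimated at 262%, in a range from 230% to 295%.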

Compound 4, largest response reached (Emax), in percent of the reference or control that the assay uses: 233%
The estimate for compound 4 lay 29 percentage points above the measured number; the measured number falls inside the stated range.
By their numbers in this assay, from the lowest: compound 4; then compounds 2 and 1 (each within the scatter of the next); then compound 3.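

The chain on the aromatic nitrogen is not a neutral spot in this assay: the change gives a number 33 percentage points lower from compound 3 to compound 4 (beyond the scatter), the first step measured at this position. Isobutyl and cyclobutyl both hold four carbons and neither has hydrogen-bond donors or acceptors, so a change that leaves those counts alone and only adds a four-membered ring still gives a large step, while the steps beyond the scatter on the oxygen side were modest. Nothing measured here accounts for this fall.

As far as these compounds go, whether the fall comes from having a ring at all or from this ring size stays open, and cyclopropyl, cyclopentyl or an open n-butyl chain in the same place would bear on that. Also open, from the compounds shown here alone, is how an ether oxygen or an amine in this chain would read, and whether the step holds with pyridin-2-yl on the oxygen.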